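Closing the amine into a pyrrolidine ring on the shared core

The source may report more compounds than this note shows. Statements on the series, on what has been measured and on what is new or still open speak of the compounds shown alone.

Measured compounds:
- compound 1 `O=C1C=C(NC2CCCC2)C(=O)c2c1nc1n2[C@H]2OC[C@@H](O)[C@H]2OC1`: > 16000 nM
- compound 2 `O=C1C=C(Nc2ccc(C(F)(F)F)cc2)C(=O)c2c1nc1n2[C@H]2OC[C@@H](O)[C@H]2OC1`: > 8000 nM
- compound 3 `CCOc1ccccc1NC1=CC(=O)c2nc3n(c2C1=O)[C@H]1OC[C@@H](O)[C@H]1OC3`: 6040 nM

In a functional assay on HeLa cells (Homo sapiens) for inhibition, read by sulforhodamine B assay (on this read-out lower numbers stand for stronger inhibition and higher numbers for weaker inhibition), compound 1 gives only a limit, > 16000 nM, so its true number is not known. Compound 2 also stops at a limit, > 8000 nM. Compound 3 gives a real number, 6040 nM. Within this small set compound 1 sits at the limit (the limit of > 16000 nM in this assay, at which 1 of the 3 values shown sits), with nothing more precise on record for it.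

Compound 4 `O=C1C=C(N2CCCC2)C(=O)c2c1nc1n2[C@H]2OC[C@@H](O)[C@H]2OC1` differs from compound 1 in one place: pyrrolidin-1-yl in place of cyclopentylamino on a double-bonded ring carbon.

Two measured steps start from compound 1. The step of an at least 2.6-fold lower number from compound 1 to compound 3 (0.42 log units; beyond the scatter) and the unreadable step that the two limits leave unreadable from compound 1 to compound 2 both swap the cyclopentyl for an aryl group and keep the amine nitrogen unchanged; neither resembles the change to pyrrolidin-1-yl. Among the compounds with values here, with compound 1 already at a limit and no comparable step in the set, the expectation in this assay for compound 4 is a number near the limit again, which means an expected step that the limit leaves unreadable from compound 1 to compound 4. The estimated value for compound 4 is 20000 nM, with a range from 6000 nM to 60000 nM.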

Compound 4, half-maximal inhibitory concentration: > 16000 nM
Compound 4: no number, only a limit; the forecaster's own chance of this, stated with the estimate: 80%; the middle value is on the limit's open side.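

Compound 4 gives only a limit, > 16000 nM, not a number. Compound 1 gives only the same limit, so the step from one to the other cannot be read: the limit of > 16000 nM in this assay, at which 2 of the 4 values shown sit.

From the compounds shown here alone, whether pyrrolidin-1-yl in place of cyclopentylamino changes the true number, and in which direction, stays open.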